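From piperidin-1-yl to pyrrolidin-1-yl on the shared core

A few compounds are considered here, and "the series" means these few. Any claim that something is new, unique, unknown or untested is made for them only; others in the source may bear on it.

These compounds share one core and differ in the group on a saturated chain carbon bound to an aromatic carbon. In a functional assay on A2780 cells (Homo sapiens) for inhibition (a lower number here means a stronger inhibitor, a higher number a weaker inhibitor), compound 2 `CCNC(=O)c1noc(-c2cc(C(C)C)c(O)cc2O)c1-c1cc(CN(C)C)no1` gives 31 nM and compound 3 `CCNC(=O)c1noc(-c2cc(C(C)C)c(O)cc2O)c1-c1cc(CN2CCCCC2)no1` gives 62 nM in the same test. Compound 1 `CCNC(=O)c1noc(-c2cc(C(C)C)c(O)cc2O)c1-c1cc(COCC(=O)O)no1` has the entry "not determined" (no result reported) here, so it adds no number to the comparison. Compound 3 therefore has a single measured neighbour, and the two numbers lie within the scatter of each other.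

Compound 4 `CCNC(=O)c1noc(-c2cc(C(C)C)c(O)cc2O)c1-c1cc(CN2CCCC2)no1` is still unmeasured. It carries pyrrolidin-1-yl in place of piperidin-1-yl at that same place, and the counted difference pyrrolidin-1-yl in place of piperidin-1-yl on a saturated chain carbon bound to an aromatic carbon is all that separates it from compound 3.

Within the data shown here, only one measured step bears on this exchange: a 2.0-fold higher number from compound 2 to compound 3 (0.30 log units; within the scatter) for piperidin-1-yl in place of dimethylamino. That single exchange stayed within the scatter, so no step beyond the scatter is expected in this assay for the new one, though one step is thin evidence. The estimated step is a 1.4-fold lower number from compound 3 to compound 4 (0.14 log units; within the scatter) in this test. For compound 4 the estimated value is 45 nM with an expected range from 20 nM to 100 nM in this measurement.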

Compound 4, half-maximal inhibitory concentration: 55 nM
Compound 4: middle estimate off by 1.2-fold (0.09 log units), on the low side; the range from low to high includes it.
By their numbers in this assay, from the lowest: compounds 2, 4 and 3 (each within the scatter of the next).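

In this assay pyrrolidin-1-yl in place of piperidin-1-yl gives a 1.1-fold lower number from compound 3 to compound 4 (0.05 log units; within the scatter) and pyrrolidin-1-yl in place of dimethylamino gives a 1.8-fold higher number from compound 2 to compound 4 (0.25 log units; within the scatter) on the same saturated chain carbon bound to an aromatic carbon. Until now this position had offered only one comparison, whereas compound 2, compound 3 and compound 4 now give three pairs that all lie within the scatter, across an open-chain group and both a six-membered and a five-membered ring, so among these three compounds neither ring size nor the ring itself moves the number beyond the usual variation between repeats. Nothing measured here offers a reason for this flat result.

These three compounds cannot show whether the same holds for a group that adds a second hetero atom to the ring, such as morpholin-4-yl, for a primary amine, or for a longer chain between the amine and the aromatic ring. As far as these compounds go, a group of a different kind also remains open, since compound 1, whose chain ends in a carboxylic acid, has the entry "not determined" (no result reported) and so gives no number to compare.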